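Butyl to (carboxymethyl)amino on two related cores

A few compounds are considered here, and "the series" means these few. Any claim that something is new, unique, unknown or untested is made for them only; others in the source may bear on it.

Measured compounds:
compound 1 `CCCCC(=O)c1ccc(C(CC)(CC)c2ccc(C#CC(O)(CC)CC)c(C)c2)n1CC`: > 50000 nM
compound 2 `CCn1c(C(=O)NCC(=O)O)ccc1C(CC)(CC)c1ccc(C#CC(O)(CC)CC)c(C)c1`: 5140 nM
compound 3 `CCCCC(=O)c1cc(C(CC)(CC)c2ccc(C#CC(O)(CC)CC)c(C)c2)cn1CC`: > 50000 nM

In a functional assay on MCF7 cells (Homo sapiens) for antiproliferative activity, read by MTT assay, with a stated time of 72 h (a lower number here means a stronger inhibitor, a higher number a weaker inhibitor), compound 1 gives only a limit, > 50000 nM. Compound 2 gives 5140 nM in this assay. The step of an at least 9.7-fold lower number from compound 1 to compound 2 (0.98 log units; beyond the scatter) follows the change ((carboxymethyl)amino in place of butyl on a carbonyl carbon). Compound 3 likewise gives only a limit in this assay, > 50000 nM. The difference between the core of compound 3 and the core of compound 1 is not broken down here. Compound 4 `CCn1cc(C(CC)(CC)c2ccc(C#CC(O)(CC)CC)c(C)c2)cc1C(=O)NCC(=O)O` arises from compound 3 through ((carboxymethyl)amino in place of butyl on a carbonyl carbon), the same change made from compound 1 to compound 2, at a place described in the same words. From the compounds shown here alone, because compound 1 and compound 3 both sit at the limit of > 50000 nM in this assay, at which 2 of the 3 values shown sit, the true size of the step from compound 3 is unknown. A step of an at least 6.2-fold lower number from compound 3 to compound 4 (0.79 log units; beyond the scatter) is expected, resting on the measured at least 9.7-fold lower number from compound 1 to compound 2 (0.98 log units; beyond the scatter). Compound 4 is estimated at 8000 nM, between 1500 nM and 50000 nM.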

Compound 4, half-maximal inhibitory concentration: 17500 nM
Beside the measured number, compound 4's estimate is 2.2-fold (0.34 log units) below it; low and high end bracket the measured number.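

In this assay, putting (carboxymethyl)amino in place of butyl on a carbonyl carbon goes with an at least 2.8-fold lower number from compound 3 to compound 4 (0.45 log units; beyond the scatter), so the direction of the step holds on both cores shown. Its size cannot be carried from one core to the other, since compound 1 and compound 3 are both known only as limits and the two steps cannot be compared: the same change on two cores in this assay, an at least 9.7-fold lower number (0.98 log units; beyond the scatter) from compound 1 to compound 2 and an at least 2.8-fold lower number (0.45 log units; beyond the scatter) from compound 3 to compound 4; the limit leaves it open whether they differ. The true starting point of each step therefore stays hidden at the same limit: the limit of > 50000 nM in this assay, at which 2 of the 4 values shown sit.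

The compounds shown leave open whether the change would hold with a methyl ester in place of the carboxylic acid. They also leave open what a longer chain between the amide nitrogen and the carboxylic acid would do on either core.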